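Fluoro for Hydrogen on the Hydroxyethoxyphenyl Group

The source may hold more compounds than are shown below. What is called first, only, known or untested is meant among the compounds shown, and "the series" means these compounds.

Measured compounds:
compound 1, `COc1ncc(-c2ccc3ncnc(Nc4ccc(OCCO)cc4)c3c2)cc1NS(=O)(=O)c1ccc(F)cc1F`, 2690 nM
compound 2, `COc1ncc(-c2ccc3ncnc(Nc4cnn(CCC(=O)O)c4)c3c2)cc1NS(C)(=O)=O`, 3840 nM

In a functional assay on A549 cells (Homo sapiens) for antiproliferative activity, read by sulforhodamine B assay, with a stated time of 72 h (on this read-out lower numbers stand for stronger inhibition and higher numbers for weaker inhibition), compound 1 gives 2690 nM, the lower of the two numbers recorded. Compound 2, in this assay, gives 3840 nM, and the gap between the two lies within the usual scatter, so the data do not separate them. The two compounds also differ in several places at once, so nothing can be read from them about any single change.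

Compound 3, `COc1ncc(-c2ccc3ncnc(Nc4ccc(OCCO)c(F)c4)c3c2)cc1NS(=O)(=O)c1ccc(F)cc1F`, is not yet measured. It differs from compound 1 in one place: fluoro in place of hydrogen on an aromatic carbon. Within the data shown here, no pair of measured compounds shows what a fluoro for hydrogen at this position does here, so there is no measured step to lean on. With only a single fluorine entering and nothing else altered, the expected step in this assay from compound 1 to compound 3 is small and within the scatter, a 1.2-fold lower number from compound 1 to compound 3 (0.07 log units; within the scatter), with no direction that can be claimed. Compound 3 is therefore estimated at 2300 nM, with a range from 800 nM to 6500 nM.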

Compound 3, half-maximal inhibitory concentration: 6640 nM
Estimate against measurement, compound 3: 2.9-fold (0.46 log units) below; measured number outside the range, above it.
By their numbers in this assay, from the lowest: compounds 1, 2 and 3 (each within the scatter of the next, the first and the last beyond it).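

In this assay, the pair gives the first measured reading of a single change among these compounds: fluoro in place of hydrogen on an aromatic carbon, ortho to a 2-hydroxyethoxy group, gives a 2.5-fold higher number from compound 1 to compound 3 (0.39 log units; beyond the scatter). On the 4-(2-hydroxyethoxy)phenyl group of compound 1, then, this position is not indifferent to substitution, since one fluorine with nothing else altered is enough to give weaker inhibition by a step beyond the scatter. The data shown offer no measured explanation for this step.

This single pair shows only what a fluoro does at this one position on this one background, so it sets no rule for the series. Going by these compounds, it remains open whether a chloro, a methyl or a methoxy at the same position would give a similar step, and whether the fluoro step would hold if an amine, a carboxylic acid or a longer chain took the place of the 2-hydroxyethoxy group.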